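The compounds below may be only part of what the source reports. "The series", "measured", "known", "first", "only" and "open" are said of these compounds alone.

Measured in a functional assay with Homo sapiens as the target; a lower number here means a stronger inhibitor, a higher number a weaker inhibitor:
- Compound 1 `CC(C)[C@H](NC(=O)COc1cccc2ccccc12)C(=O)N[C@@H](CC(=O)O)C(=O)COc1cccc2ccccc12`: 19000 nM
- Compound 2 `CC(C)[C@H](NC(=O)COc1cccc2ccccc12)C(=O)N[C@@H](CC(=O)O)C(=O)COc1ccccc1[N+](=O)[O-]`: 27700 nM
- Compound 3 `CC(C)[C@H](NC(=O)COc1cccc2ccccc12)C(=O)N[C@@H](CC(=O)O)C(=O)COc1ccc([N+](=O)[O-])cc1`: 22800 nM

These three compounds differ only in the group on an oxygen on a saturated carbon. Compound 3, at 22800 nM, cannot be separated from the other two. The steps that reach it are a 1.2-fold higher number from compound 1 to compound 3 (0.08 log units; within the scatter) and a 1.2-fold lower number from compound 2 to compound 3 (0.08 log units; within the scatter), so all three values count as the same level of activity.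

Compound 4 `CC(C)[C@H](NC(=O)COc1cccc2ccccc12)C(=O)N[C@@H](CC(=O)O)C(=O)COc1ccc(F)cc1` changes one substituent of compound 3: fluoro in place of nitro on an aromatic carbon. This puts fluoro in place of nitro on an aromatic carbon, para to a large group.

Among the measured compounds shown here, no measured step makes this exact swap, so the evidence is indirect. Compound 3 gave a 1.2-fold lower number from compound 2 to compound 3 (0.08 log units; within the scatter) when the nitro group was placed differently on the ring. Compound 2 gave a 1.5-fold higher number from compound 1 to compound 2 (0.16 log units; within the scatter) when a whole naphthalen-1-yl group was replaced. Three compounds are thin support, but none of these changes moved this assay beyond the scatter, so no larger step is expected here.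

For compound 4 the estimated step is a 1.1-fold lower number from compound 3 to compound 4 (0.04 log units; within the scatter). Compound 4 is expected to read about 21000 nM, with an estimated range from 10000 nM to 44000 nM.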

Compound 4, half-maximal inhibitory concentration: 14300 nM
Estimate against measurement, compound 4: 1.5-fold (0.17 log units) above; low and high end bracket the measured number.
By their numbers in this assay, from the lowest: compounds 4, 1, 3 and 2 (each within the scatter of the next).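

Fluoro in place of nitro is the only step shown that exchanges the substituent itself on this phenyl ring, rather than moving it or replacing the whole aromatic group, and in this assay it gives a 1.6-fold lower number from compound 3 to compound 4 (0.20 log units; within the scatter). The wider comparisons also stay within the scatter, with a 1.9-fold lower number from compound 2 to compound 4 (0.29 log units; within the scatter) and a 1.3-fold lower number from compound 1 to compound 4 (0.12 log units; within the scatter), so 4-fluorophenyl joins 2-nitrophenyl, 4-nitrophenyl and naphthalen-1-yl at one level of activity, and the nitro group is not needed at this position to hold that level. Nothing measured alongside these compounds offers an explanation for why the four groups read alike.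

Going by these compounds, it remains open whether any substituent at this place, para to a large group, can move the number beyond the scatter, for example an amine, a carboxylic acid or a methoxy group. On these data alone, all four compounds also share the same core, so it is equally open whether a change elsewhere on it, such as a longer chain, would matter more than the changes on this ring.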